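This account rests on a few compounds, and the source may have more. Where it says the series, first, only, none or still open, it means among the compounds named here.

The series shares one fused core and is read in a functional assay on Ehrlich cells (Mus musculus) for cytotoxicity, read by trypan blue exclusion, with a stated time of 2 h, tested at 100 ug/mL; a higher number here means a weaker effect of the compound at the concentration tested, a lower number a stronger effect. Compound 1, `N#Cc1c(N)[n+]([O-])c2ccc(Cl)cc2[n+]1[O-]`, gives 94% in this assay. Compound 2, `CNc1c(C#N)[n+]([O-])c2cc(Cl)ccc2[n+]1[O-]`, gives 89% in this assay. Among the measured compounds shown here, the only measured step, a number 5 percentage points lower from compound 1 to compound 2 (within the scatter), leaves compound 2 with the lowest of the two numbers, its nearest neighbour being compound 1 at a distance that lies within the scatter, so no order between the two can be claimed.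

Compound 3, `CC(=O)N(C(C)=O)c1c(C#N)[n+]([O-])c2cc(Cl)ccc2[n+]1[O-]`, has not yet been measured. It differs from compound 2 by diacetylamino in place of methylamino on an aromatic carbon. For the measured compounds named here, the single measured step, a number 5 percentage points lower from compound 1 to compound 2 (within the scatter), was a smaller alteration of the same group and did not move this assay beyond the scatter. The change to compound 3 is larger, yet the two measured compounds offer nothing that points in either direction. The expected step is therefore a number 3 percentage points lower from compound 2 to compound 3 (within the scatter), small and without a firm direction, and a wide range is kept. Compound 3 is accordingly estimated to give 86% in this assay, with a range from 66% to 99%.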

Compound 3, a percentage reported as activity, at one concentration (the size of the read-out at that concentration, not a potency): 77.7%
Compound 3: the middle estimate sits 8.3 percentage points above what was measured; the range from low to high includes it.
By their numbers in this assay, from the lowest: compound 3; then compounds 2 and 1 (each within the scatter of the next).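

At the aromatic carbon next to the ring nitrogen and ortho to a cyano group, diacetylamino in place of methylamino gives a step in this assay that, unlike the earlier one, clears the scatter: a number 11.3 percentage points lower from compound 2 to compound 3 (beyond the scatter). Diacetylamino in place of amino tells the same story, with a number 16.3 percentage points lower from compound 1 to compound 3 (beyond the scatter), so this position responds to the group it carries, although the methyl on the nitrogen did not separate compound 1 from compound 2. The lower number means a stronger effect at the single concentration tested, but the step is modest and no measurement here accounts for it.

From the compounds shown here alone, whether a single acetylamino group would already reach the number of compound 3, or both acetyl groups are needed, remains open, as does whether dimethylamino or a longer acyl chain such as dipropionylamino would behave alike at this carbon. Each compound is read at one concentration only, so these numbers give the size of the effect at that concentration and say nothing about the effect of compound 3 at any other.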